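This account rests on a few compounds, and the source may have more. Where it says the series, first, only, none or still open, it means among the compounds named here.

Compound 1 `CCCCC(CC)C(=O)Nc1ccc2ccn(Cc3ccc(C(=O)NS(=O)(=O)c4ccc(Cl)cc4)cc3OC)c2c1`: 7.8
Compound 2 `COC(=O)C(C(=O)c1ccc(Cn2ncc3ccc(NC(=O)OC4CCCC4)cc32)c(OC)c1)S(=O)(=O)c1ccccc1`: 9.9
Compound 3 `COc1cc(C(=O)NS(=O)(=O)c2ccccc2C)ccc1Cn1ncc2ccc(NC(=O)CC3CCCC3)cc21`: 10.9

These three compounds were tested in a functional assay (trachea) for antagonist activity, with Cavia porcellus as the target; on this read-out higher numbers stand for higher potency (the scale is a negative logarithm) and lower numbers for lower potency. Compound 1 stands lowest of the three; compound 2 gives a number well above it, beyond the usual scatter, and compound 3 lies higher still. No two of the measured compounds differ in just one place, so no single-point step can be read from them.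

Compound 4 `CCCCC(CC)C(=O)Nc1ccc2ccn(Cc3ccc(C(=O)C(C#N)S(=O)(=O)c4ccccc4)cc3OC)c2c1` is compound 1 with one change: cyano(phenylsulfonyl)methyl in place of ((4-chlorophenyl)sulfonyl)amino on a carbonyl carbon. Compound 2, which also pairs a carbonyl with a sulfonyl-bearing carbon, scores high, though it differs from compound 1 elsewhere too, so only a cautious rise is expected. The step from a number 0.70 log units higher from compound 1 to compound 4 (beyond the scatter) is expected to be a modest gain. Compound 4 is therefore estimated at 8.5, likely between 7.6 and 9.4.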

Compound 4, negative logarithm of the antagonist equilibrium constant: 8.1
Compound 4: the middle estimate sits 0.40 log units above what was measured; measured number inside the range.
By their numbers in this assay, from the lowest: compounds 1 and 4 (each within the scatter of the next); then compound 2; then compound 3.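

In this assay the carbonyl carbon takes cyano(phenylsulfonyl)methyl in place of ((4-chlorophenyl)sulfonyl)amino, giving a number 0.30 log units higher from compound 1 to compound 4 (within the scatter) and showing that the two groups read alike at this position. The leaving group carries a hydrogen-bond donor and a chlorine while the entering group carries neither, yet the two numbers stay within the scatter. Nothing shown explains this result.

Still open, as far as these compounds go, is whether a carboxylic acid or a simple amine on this carbonyl carbon would match these numbers. Also open, from the compounds shown here alone, is whether the nitrile or the phenylsulfonyl part of the entering group matters more.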